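A methoxy for a methyl: what to expect

A few compounds are considered here, and "the series" means these few. Any claim that something is new, unique, unknown or untested is made for them only; others in the source may bear on it.

Measured so far in an ADME assay on NIH3T3 cells (Mus musculus) for inhibition, read by MTT assay, with a stated time of 48 h; on this read-out lower numbers stand for stronger inhibition and higher numbers for weaker inhibition:
Compound 1 `CS(=O)(=O)c1ccc(-c2nc3ccccn3c2Sc2ccccc2)cc1`: > 100000 nM
Compound 2 `Cc1ccc(-c2nc3ccccn3c2Sc2ccccc2)cc1`: > 100000 nM

Compound 2 gives > 100000 nM in this assay, and this is a limit of the assay, not a number. Compound 1 gives > 100000 nM, which is also a limit. The evidence so far is therefore (the limit of > 100000 nM in this assay, at which 2 of the 2 values shown sit).

Compound 3 `COc1ccc(-c2nc3ccccn3c2Sc2ccccc2)cc1` differs from compound 2 by one change, 4-methylphenyl to 4-methoxyphenyl: methoxy in place of methyl on an aromatic carbon. For the measured compounds named here, the only measured step is a step that the two limits leave unreadable from compound 1 to compound 2, so it offers no size to carry over and no direction to follow. No step beyond the usual scatter is therefore expected in this assay, and another limit is the likeliest report. The estimated step is a number no higher from compound 2 to compound 3 (the limit leaves the size open). For compound 3 the expected value is 100000 nM, with an estimated range from 40000 nM to 200000 nM.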

Compound 3, half-maximal inhibitory concentration: 91700 nM
For compound 3 the middle estimate is 1.1-fold (0.04 log units) above the measured one; the range from low to high includes it.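

In this assay, for the compounds shown here, compound 3 gives 91700 nM, the first actual number in this set rather than a limit. As far as these compounds go, the change at this aromatic carbon, para to a large group, reads as an at least 1.0-fold lower number from compound 2 to compound 3 (0.03 log units; that floor lies within the scatter), and the swap from methylsulfonyl to methoxy reads as an at least 1.0-fold lower number from compound 1 to compound 3 (0.03 log units; that floor lies within the scatter), so neither step shows a real difference, though the true size of each remains unknown. Most of the data still sit at the top of the measurable range: the limit of > 100000 nM in this assay, at which 2 of the 3 values shown sit.

From the compounds shown here alone, whether an amine, a carboxylic acid or a longer chain such as ethoxy at this position would bring the number down by more than the usual scatter remains open. Also open, going by these compounds, is whether a change elsewhere on the shared core would do so.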